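The compounds below may be only part of what the source reports. "The series", "measured", "known", "first", "only" and "open" are said of these compounds alone.

In a functional assay on A549 cells (Homo sapiens) for inhibition, read by sulforhodamine B assay, with a stated time of 48 h (on this read-out lower numbers stand for stronger inhibition of growth and higher numbers for weaker inhibition of growth), three compounds built on a shared core have been measured so far. Compound 1 `COc1cc(-c2nn(-c3cccc(NC(=O)Nc4ccc(Cl)c(Cl)c4)c3)cc2-c2ccncc2)ccc1Cl` gives 745 nM, and compound 2 `COc1cc(-c2nn(-c3cccc(NC(=O)Nc4cccc(C(F)(F)F)c4)c3)cc2-c2ccncc2)ccc1Cl` gives 794 nM; the step of a 1.1-fold higher number from compound 1 to compound 2 (0.03 log units; within the scatter) lies within the scatter, so the two ureas cannot be told apart on this read-out. Compound 3 `COc1cc(-c2nn(-c3cccc(NC(=O)c4ccc(Cl)c(C(F)(F)F)c4)c3)cc2-c2ccncc2)ccc1Cl` gives 2400 nM, the highest of the three numbers. Its distance from the ureas is shown by the steps of a 3.2-fold higher number from compound 1 to compound 3 (0.51 log units; beyond the scatter) and a 3.0-fold higher number from compound 2 to compound 3 (0.48 log units; beyond the scatter), both modest but beyond the scatter. In each of these an aryl amide stood in place of an aryl urea, and in each the number rose by about the same amount.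

Compound 4 `COc1cc(-c2nn(-c3cccc(NC(=O)Nc4ccc(Cl)c(C(F)(F)F)c4)c3)cc2-c2ccncc2)ccc1Cl` has not yet been measured. It differs from compound 3 by (4-chloro-3-(trifluoromethyl)phenyl)amino in place of 4-chloro-3-(trifluoromethyl)phenyl on a carbonyl carbon: the amide of compound 3 becomes a urea, which is the change shown by the two measured steps to compound 3, read in the opposite direction. Those two steps therefore bear directly on this one, and a modest lowering of the number in this assay, of about their size, is expected. The estimate for compound 4 is 800 nM, with a range from 400 nM to 1600 nM. For compound 4 this expected step amounts to a 3.0-fold lower number from compound 3 to compound 4 (0.48 log units; beyond the scatter).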

Compound 4, concentration for 50% growth inhibition: 1020 nM
The estimate for compound 4 lay 1.3-fold (0.11 log units) below the measured number, within the range that was stated.
By their numbers in this assay, from the lowest: compounds 1, 2 and 4 (each within the scatter of the next); then compound 3.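

Going by these compounds alone, with the 4-chloro-3-(trifluoromethyl)phenyl group held the same on both sides, the change from amide to urea on this carbonyl carbon gives a 2.4-fold lower number from compound 3 to compound 4 (0.37 log units; beyond the scatter) in this assay, beyond the scatter; the earlier steps to compound 3 had changed the aryl group at the same time, so this is the first view of the linker change alone. Within the ureas, the added chloro gives a 1.3-fold higher number from compound 2 to compound 4 (0.11 log units; within the scatter) and trifluoromethyl in place of chloro gives a 1.4-fold higher number from compound 1 to compound 4 (0.14 log units; within the scatter), both within the scatter, so compound 1, compound 2 and compound 4 cannot be told apart on this read-out, whichever of these aryl groups they carry. Nothing measured here bears on what lies behind the difference between the amide and the urea.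

The compounds shown leave open whether a carbamate or a sulfonamide on this position would read like the ureas or like the amide, and what a methyl group on a urea nitrogen would do. They also leave open whether a methoxy group or a morpholine on the aryl ring of the urea would separate from these halogen-bearing rings.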